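The source may hold more compounds than are shown below. What is called first, only, known or untested is meant among the compounds shown, and "the series" means these compounds.

Measured so far:
- compound 1 `Cc1ccc(NC(=O)/C=C/c2ccccc2)c(C(N)=O)c1`: 5500 nM
- compound 2 `NC(=O)c1cc(Br)ccc1NC(=O)/C=C/c1ccccc1Cl`: 8100 nM

Both numbers come from a functional assay on K562 cells (Homo sapiens) for inhibition, read by trypan blue exclusion, with a stated time of 48 h (a higher number here means a weaker inhibitor, a lower number a stronger inhibitor), and the read-out is the half-maximal inhibitory concentration. Compound 2, at 8100 nM, lies within the scatter of compound 1, so the two cannot be told apart on these data.

The next compound to be tested is compound 3 `NC(=O)c1cc(Br)ccc1NC(=O)/C=C/c1ccccc1Br`, which has no number yet. It differs from compound 2 in one place: bromo in place of chloro on an aromatic carbon. In words, this is bromo in place of chloro on an aromatic carbon, so that 2-chlorophenyl becomes 2-bromophenyl.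

Within the data shown here, no measured pair shows a single change of this kind, so the data offer no direct guide to its size or direction. The only anchor is the level of compound 2 at 8100 nM. A step beyond the scatter is not expected, and neither direction is favoured. The estimated 1.1-fold lower number from compound 2 to compound 3 (0.03 log units; within the scatter) therefore stays within the scatter. For compound 3 the expected value is 7500 nM, with a range from 4000 nM to 14000 nM.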

Compound 3, half-maximal inhibitory concentration: > 10000 nM
Compound 3 gave a limit, no number; the forecaster's own chance of this, stated with the estimate: 5%; middle value at least 1.3-fold (0.12 log units) from the limit.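

In this assay compound 3 gives > 10000 nM, which is a limit of the assay and not a number. Bromo in place of chloro on an aromatic carbon, ortho to a large group, gives an at least 1.2-fold higher number from compound 2 to compound 3 (0.09 log units; that floor lies within the scatter), so this first single change in the series brings no gain in strength at this position, although its floor alone does not separate the two compounds. How far the true value of compound 3 lies from that of compound 2 cannot be read, and the step may be small or large: the limit of > 10000 nM in this assay, at which 1 of the 3 values shown sits.

The compounds shown leave open how fluoro, methoxy or an amine would read at this same place in this assay, and so whether any group there can bring the number down. Compound 1 differs from compound 2 and compound 3 in more than one place, so it cannot show what either the 2-chlorophenyl or the 2-bromophenyl group contributes alone.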